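The source may report more compounds than this note shows. Statements on the series, on what has been measured and on what is new or still open speak of the compounds shown alone.

Working notes on the series. In an in vitro assay on BHK cells for displacement of a labelled ligand from Alpha-1A adrenergic receptor (Bos taurus), read by scintillation counting, with a stated time of 20 min (a lower number here means a stronger inhibitor, a higher number a weaker inhibitor), compound 1 `CN1CCC(c2cn(-c3ccc(F)cc3)c3ccc(-c4ccnn4C)cc23)CC1` gives 0.32 nM. Compound 2 `CN1CCC(c2cn(-c3ccncc3)c3ccc(-c4ccnn4C)cc23)CC1` gives 19 nM in this assay, and compound 3 `CN1CCC(c2cn(-c3ccc(F)cc3)c3ccc(-c4cnn(C)c4)cc23)CC1` gives 2.7 nM. On these three numbers compound 3 stands second highest, sitting between compound 1, which gives the lowest number, and compound 2, which gives the highest. The two measured steps from a common starting point are a 59-fold higher number from compound 1 to compound 2 (1.77 log units; beyond the scatter) and an 8.4-fold higher number from compound 1 to compound 3 (0.93 log units; beyond the scatter), both beyond the scatter.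

Compound 4 `CN1CCC(c2cn(-c3ccncc3)c3ccc(-c4cnn(C)c4)cc23)CC1` has not yet been measured in this assay. It differs from compound 3 in one place: pyridin-4-yl in place of 4-fluorophenyl on an aromatic nitrogen. The same exchange has been seen once in the series, in the step of a 59-fold higher number from compound 1 to compound 2 (1.77 log units; beyond the scatter), which was large. The other measured step, an 8.4-fold higher number from compound 1 to compound 3 (0.93 log units; beyond the scatter), does not bear on this exchange directly; it only fixes the starting point, compound 3, from which compound 4 departs. Going by the values given here, no measured pair shows whether the two exchanges combine additively, so the expectation rests on the single precedent. Compound 4 is therefore expected to give a markedly higher number than compound 3, with the step estimated as a 59-fold higher number from compound 3 to compound 4 (1.77 log units; beyond the scatter). The estimate for compound 4 in this assay is 160 nM, with a range from 50 nM to 500 nM.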

Compound 4, inhibition constant: 38 nM
Compound 4: middle estimate off by 4.2-fold (0.62 log units), on the high side; the whole stated range lies above it.
By their numbers in this assay, from the lowest: compound 1; then compound 3; then compounds 2 and 4 (each within the scatter of the next).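

In this assay, the exchange of 4-fluorophenyl for pyridin-4-yl on the aromatic nitrogen now reads on a second core (a 14-fold higher number from compound 3 to compound 4 (1.15 log units; beyond the scatter)), so it raises the number on both cores shown, but by a size that changes with the pyrazole the core carries: the same change on two cores in this assay, a 59-fold higher number (1.77 log units; beyond the scatter) from compound 1 to compound 2 and a 14-fold higher number (1.15 log units; beyond the scatter) from compound 3 to compound 4, 4.2-fold (0.63 log units) apart, beyond the scatter of two such steps. Seen from the pyrazole, the exchange of 1-methyl-1H-pyrazol-5-yl for 1-methyl-1H-pyrazol-4-yl is beyond the scatter with 4-fluorophenyl on the nitrogen but not with pyridin-4-yl (a 2.0-fold higher number from compound 2 to compound 4 (0.30 log units; within the scatter)), so the two exchanges do not simply add: the same change on two cores in this assay, an 8.4-fold higher number (0.93 log units; beyond the scatter) from compound 1 to compound 3 and a 2.0-fold higher number (0.30 log units; within the scatter) from compound 2 to compound 4, 4.2-fold (0.63 log units) apart, beyond the scatter of two such steps. With pyridin-4-yl in this place, the two pyrazoles are therefore not told apart in this assay, and the benefit of 1-methyl-1H-pyrazol-5-yl appears only in the pair carrying 4-fluorophenyl.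

As far as these compounds go, only these two groups appear on the aromatic nitrogen, so it stays open whether the higher numbers follow from the ring nitrogen of pyridin-4-yl or from the loss of the fluorine, a question that a plain phenyl in this place would separate. Also open, from the compounds shown here alone, is whether the same interplay holds with a pyridin-3-yl group on that nitrogen, or with a piperidin-4-yl group lacking the methyl on the core.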